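The source may hold more compounds than are shown below. What is called first, only, known or untested is meant among the compounds shown, and "the series" means these compounds.

Measured in a functional assay on RAW264.7 cells (Mus musculus) for inhibition, read by Griess assay, with stated times of 1 h and 24 h; on this read-out higher numbers stand for weaker inhibition and lower numbers for stronger inhibition:
Compound 1 `O=C1CC(c2ccccc2OCc2ccccc2)Oc2ccccc21` gives 18900 nM.
Compound 2 `C=CCOc1ccccc1C1CC(=O)c2ccccc2O1` gives 37800 nM.
Compound 3 `O=C1CC(c2ccccc2OCc2ccc(F)cc2)Oc2ccccc21` gives 28200 nM.

Compound 3 stands second highest of these three numbers; compound 2 is nearest and compound 1 furthest, and neither gap goes beyond the scatter, so the three compounds cannot be ranked against each other on this read-out. Compound 4 `CCOc1ccccc1C1CC(=O)c2ccccc2O1` follows from compound 3 by one change: methyl in place of 4-fluorophenyl on a saturated chain carbon bound to an oxygen on an aromatic ring. Within the data shown here, two measured steps bear on it. The step of a 2.0-fold higher number from compound 1 to compound 2 (0.30 log units; within the scatter), vinyl in place of phenyl on a saturated chain carbon bound to an oxygen on an aromatic ring, is the closest parallel, replacing a ring with a short chain at the same place. The step of a 1.3-fold lower number from compound 2 to compound 3 (0.13 log units; within the scatter), 4-fluorophenyl in place of vinyl at that place, runs the other way. Among the measured compounds shown here, both lie within the scatter, and no measured compound carries anything as small as methyl at this place. The expected step is therefore small, leaning toward a higher number, a 1.5-fold higher number from compound 3 to compound 4 (0.17 log units; within the scatter). Compound 4 is estimated at 42000 nM, within a range of 18000 nM to 95000 nM.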

Compound 4, half-maximal inhibitory concentration: 38500 nM
Compound 4: middle estimate off by 1.1-fold (0.04 log units), on the high side; measured number inside the range.
By their numbers in this assay, from the lowest: compounds 1, 3, 2 and 4 (each within the scatter of the next, the first and the last beyond it).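

At this place, on a saturated chain carbon bound to an oxygen on an aromatic ring, this assay now yields its first step beyond the scatter: methyl in place of phenyl gives a 2.0-fold higher number from compound 1 to compound 4 (0.31 log units; beyond the scatter) and is a modest step. Methyl in place of 4-fluorophenyl gives a 1.4-fold higher number from compound 3 to compound 4 (0.14 log units; within the scatter) and methyl in place of vinyl gives a 1.0-fold higher number from compound 2 to compound 4 (0.01 log units; within the scatter) and both stay within the scatter, so among the four compounds only compound 1 and compound 4 are set apart. No measurement in hand offers an explanation for these steps.

Going by these compounds, what a longer chain, an amine or a carboxylic acid would do at this place remains open. On these data alone, all four compounds also keep the shared core, so the effect of any change there is unknown.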